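Isopropyl for Methyl on the Amide of Compound 3

The compounds below may be only part of what the source reports. "The series", "measured", "known", "first", "only" and "open" are said of these compounds alone.

Three compounds sharing one core have been tested in a functional assay on HCT-116 cells (Homo sapiens) for cytotoxicity, read by MTT assay, with a stated time of 48 h; a lower number here means a stronger inhibitor, a higher number a weaker inhibitor:

Compound 1, `CNC(=O)c1cc(Oc2cccc(NC(=S)Nc3ccc(Cl)cc3)c2)ccn1`, gives 39400 nM in this assay.
Compound 2, `CC(C)NC(=O)c1cc(Oc2cccc(NC(=S)Nc3ccc(Cl)cc3)c2)ccn1`, gives 22100 nM in this assay.
Compound 3, `CNC(=O)c1cc(Oc2cccc(NC(=S)Nc3ccc(OC(F)(F)F)cc3)c2)ccn1`, gives 33800 nM in this assay.

Compound 3 stands second highest of these three numbers; its nearest neighbour is compound 1 and the furthest is compound 2, and both gaps lie within the scatter of repeated measurements. The step from compound 1 to compound 3 swaps trifluoromethoxy for chloro on an aromatic carbon, with a 1.2-fold lower number from compound 1 to compound 3 (0.07 log units; within the scatter).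

Compound 4, `CC(C)NC(=O)c1cc(Oc2cccc(NC(=S)Nc3ccc(OC(F)(F)F)cc3)c2)ccn1`, has not yet been measured. It differs from compound 3 in one place: isopropyl in place of methyl on an amide-type nitrogen. The same exchange has been seen once already, from compound 1 to compound 2, on the core that carries chloro rather than trifluoromethoxy, and there it gave a 1.8-fold lower number from compound 1 to compound 2 (0.25 log units; within the scatter). Among the measured compounds shown here, that earlier step is the only direct guide, and it stayed within the scatter, so no change beyond the scatter is expected in this assay for compound 4; if anything, a slightly lower number, in the direction seen before.

The number for compound 4 is therefore expected near 21000 nM, with a range from 9000 nM to 48000 nM, which corresponds to an expected step of a 1.6-fold lower number from compound 3 to compound 4 (0.21 log units; within the scatter).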

Compound 4, half-maximal inhibitory concentration: 18100 nM
For compound 4 the middle estimate is 1.2-fold (0.06 log units) above the measured one; the range from low to high includes it.
By their numbers in this assay, from the lowest: compounds 4, 2, 3 and 1 (each within the scatter of the next, the first and the last beyond it).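

In this assay, the exchange of methyl for isopropyl on the amide-type nitrogen can now be read on a second core, the one carrying trifluoromethoxy rather than chloro (a step of a 1.9-fold lower number from compound 3 to compound 4 (0.27 log units; within the scatter)), and the two readings agree: the same change on two cores in this assay, a 1.8-fold lower number (0.25 log units; within the scatter) from compound 1 to compound 2 and a 1.9-fold lower number (0.27 log units; within the scatter) from compound 3 to compound 4, 1.0-fold (0.02 log units) apart, within the scatter of two such steps.

The exchange of chloro for trifluoromethoxy on an aromatic carbon can likewise be read a second time, now with isopropyl rather than methyl on the amide (a step of a 1.2-fold lower number from compound 2 to compound 4 (0.09 log units; within the scatter)), and it too repeats: the same change on two cores in this assay, a 1.2-fold lower number (0.07 log units; within the scatter) from compound 1 to compound 3 and a 1.2-fold lower number (0.09 log units; within the scatter) from compound 2 to compound 4, 1.0-fold (0.02 log units) apart, within the scatter of two such steps.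

Each exchange therefore reads alike whichever form the other place takes, so these four compounds give no sign that the two places depend on each other, although every single step stays within the scatter.

What the compounds shown leave open is whether this position can move the number beyond the scatter at all, for instance with a cyclohexyl group or a longer chain on the amide-type nitrogen, or with a plain primary amide in place of the methylcarbamoyl group. A chain ending in an amine or a carboxylic acid at this position also lies outside what these four compounds can say.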